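Halogen changes on the benzyl ether of the shared core

The source may hold more compounds than are shown below. What is called first, only, known or untested is meant among the compounds shown, and "the series" means these compounds.

Among the measured compounds shown here, compound 2 `O=C(O)c1cccc(C2=C(c3cc(Br)ccc3OCc3ccc(Cl)cc3)CCC2)c1` carries the smaller of the two numbers recorded in an assay on isolated protein for inhibition of prostaglandin E2 receptor EP1 subtype (Homo sapiens) (a higher number here means a weaker inhibitor, a lower number a stronger inhibitor), where compound 2 gives 12.6 nM; the only other entry is compound 1 `O=C(O)c1cccc(C2=C(c3cc(Br)ccc3OCc3ccc(F)cc3)CCC2)c1`, which in this assay gives 20 nM, and the gap between them is within the scatter. For the measured compounds named here, the single measured step, a 1.6-fold lower number from compound 1 to compound 2 (0.20 log units; within the scatter), is thus not a resolved difference. Compound 3 `O=C(O)c1cccc(C2=C(c3cc(Br)ccc3OCc3ccc(F)cc3F)CCC2)c1` differs from compound 2 by 2,4-difluorophenyl in place of 4-chlorophenyl on a saturated chain carbon bound to an oxygen on an aromatic ring. Going by the values given here, the change brings back the fluoro pattern of compound 1 and adds a second fluorine to the ring; the one step bearing on it is the chloro-for-fluoro exchange between compound 1 and compound 2, which stayed within the scatter, and no measured step covers the second fluorine. The step expected here is a 1.4-fold higher number from compound 2 to compound 3 (0.15 log units; within the scatter), none beyond the scatter. Compound 3 is estimated at 18 nM in this assay, range 7 nM to 45 nM.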

Compound 3, half-maximal inhibitory concentration: 5.01 nM
Beside the measured number, compound 3's estimate is 3.6-fold (0.56 log units) above it; measured number outside the range, below it.
By their numbers in this assay, from the lowest: compound 3; then compounds 2 and 1 (each within the scatter of the next).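

In this assay, among the compounds shown here, fluoro in place of hydrogen on an aromatic carbon gives a 4.0-fold lower number from compound 1 to compound 3 (0.60 log units; beyond the scatter), the first step on this benzyl ether to lie beyond the scatter. For the compounds shown here, the exchange of 4-chlorophenyl for 2,4-difluorophenyl on the saturated chain carbon bound to an oxygen on an aromatic ring gives a 2.5-fold lower number from compound 2 to compound 3 (0.40 log units; beyond the scatter), also beyond the scatter, so this position can resolve a change in halogen substitution, which the single chloro-for-fluoro step did not show. The data shown offer no explanation for either step.

From the compounds shown here alone, whether the same response extends to a dichlorobenzyl ether remains open. So does the behaviour of this position with a non-halogen substituent on the ring, such as methoxy or nitrile, or with an amine or a longer chain in place of the benzyl group.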